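The source may report more compounds than this note shows. Statements on the series, on what has been measured and on what is new or still open speak of the compounds shown alone.

In a functional assay on HT-29 cells (Homo sapiens) (on this read-out lower numbers stand for an effect already at smaller amounts and higher numbers for an effect only at larger amounts of compound), compound 1 (`CN1CCN(C(=O)c2cc(-c3ccccc3)sc2NC(N)=O)CC1`) has the entry "not determined" (no result reported), and compound 2 (`CN(CCN)C(=O)c1cc(-c2ccccc2)sc1NC(N)=O`) has the entry "not determined" (no result reported). Among the compounds with values here, compound 3 (`NC(=O)Nc1sc(-c2ccc(C(=O)N3CCOCC3)cc2)cc1C(=O)N[C@H]1CCCNC1`) gives 610 nM, the only number available, so it cannot yet be ranked against any other compound. Compound 4 (`Cc1ccc(-c2cc(C(=O)N[C@H]3CCCNC3)c(NC(N)=O)s2)cc1`) keeps the shared core and the rest of compound 3, but carries methyl in place of (morpholin-4-yl)carbonyl on an aromatic carbon, para to a large group: methyl in place of (morpholin-4-yl)carbonyl on an aromatic carbon. Within the data shown here, no two measured compounds differ in one place only, so the data offer no precedent for this change. Among the measured compounds shown here, the only anchor is compound 3 at 610 nM, and the expectation is correspondingly loose. In this assay, a modest step towards lower numbers is expected, though it may stay within the usual scatter of repeated measurements. The expected change is a 1.4-fold lower number from compound 3 to compound 4 (0.13 log units; within the scatter). For compound 4 the estimated value is 450 nM, with an expected range from 130 nM to 1500 nM.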

Compound 4, half-maximal effective concentration: 70 nM
Beside the measured number, compound 4's estimate is 6.4-fold (0.81 log units) above it; measured number outside the range, below it.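

In this assay, within the data shown here, the only step that can be read shows that this place on the six-membered aromatic ring, para to a large group, does not need (morpholin-4-yl)carbonyl for a low number: methyl in its place gives an 8.7-fold lower number from compound 3 to compound 4 (0.94 log units; beyond the scatter). The swap removes a group of 8 heavy atoms with a non-aromatic ring and 2 hydrogen-bond acceptors and leaves a single carbon, and the number still falls rather than rises. Nothing available here accounts for why the number moves in this direction.

The compounds shown leave open whether methyl itself matters or whether a chlorine atom, an ethyl group or a methoxy group at this place would give a similar number. They also do not show what an amine or a carboxylic acid on this ring would give in this assay.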